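A phenyl swap on compound 1

A few compounds are considered here, and "the series" means these few. Any claim that something is new, unique, unknown or untested is made for them only; others in the source may bear on it.

Compound 1 `Cc1cccc(Oc2cccc(CN3CCC(n4cc(C)c(=O)[nH]c4=O)CC3)c2)c1` was tested in an ADME assay on MRC5 cells (Homo sapiens) for cytotoxicity, read by fluorescence and resazurin assay, with a stated time of 3 days; a lower number here means a stronger inhibitor, a higher number a weaker inhibitor. Compound 1 gives > 64000 nM, which is a limit of the assay and not a number. This means that there is no exact value from which to measure a change.

Two related compounds offer some context. For compound 2 `Cc1cn(C2CCN(Cc3cc(Oc4cc(Cl)cc(Cl)c4)ccn3)CC2)c(=O)[nH]c1=O`, the entry reads "not determined" (no result reported). Compound 3 `Cc1cn(C2CCN(Cc3cncc(Oc4cccc(OC(F)(F)F)c4)c3)CC2)c(=O)[nH]c1=O` gives > 64000 nM, which is again a limit.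

Compound 4 `Cc1cn(C2CCN(Cc3cccc(Oc4cc(F)cc(F)c4)c3)CC2)c(=O)[nH]c1=O` keeps the rest of compound 1 and alters one group (3,5-difluorophenyl in place of 3-methylphenyl on an oxygen on an aromatic ring). In words, it carries 3,5-difluorophenyl in place of 3-methylphenyl on an oxygen on an aromatic ring. Among the compounds with values here, no measured pair of compounds differs in just one place, so the data offer no direct guide to this swap.

Starting from compound 1, no change beyond the usual scatter is expected in this assay because of the limit of > 64000 nM in this assay, at which 2 of the 3 values shown sit. The estimated a number no higher from compound 1 to compound 4 (the limit leaves the size open) is expected to stay within that scatter. The likeliest report is therefore another limit rather than an exact number. For compound 4 the expected value is 64000 nM, with an estimated range from 30000 nM to 100000 nM.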

Compound 4, half-maximal inhibitory concentration: > 64000 nM
Compound 4 was reported as a limit; the forecaster's own chance of this, stated with the estimate: 85%; the middle value lies on the limit itself.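

No step can be read between compound 1 and compound 4, because each result is a limit of the assay and not a number: the limit of > 64000 nM in this assay, at which 3 of the 4 values shown sit.

The compounds shown leave open what exact value any of them would give in this assay, and whether 3,5-difluorophenyl in place of 3-methylphenyl makes any difference there.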